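Swapping an aryl amide for a tert-butyl amide

The source may report more compounds than this note shows. Statements on the series, on what has been measured and on what is new or still open speak of the compounds shown alone.

Measured so far:
- compound 1 `N#Cc1ccccc1NC(=O)c1[nH]cnc1-c1nc2ccccc2[nH]1`: 34200 nM
- compound 2 `N#Cc1cccc(NC(=O)c2[nH]cnc2-c2nc3ccccc3[nH]2)c1`: 24900 nM

Both compounds share one core and differ only in the group on the amide-type nitrogen. In a functional assay on MDA-MB-231 cells (Homo sapiens) for inhibition, read by MTT assay, with a stated time of 48 h (a lower number here means a stronger inhibitor, a higher number a weaker inhibitor), compound 1 gives 34200 nM, and compound 2 gives 24900 nM. The step of a 1.4-fold lower number from compound 1 to compound 2 (0.14 log units; within the scatter) is within the scatter, so compound 2 and compound 1 cannot be told apart on these numbers, and neither can be called the stronger one.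

Compound 3 `CC(C)(C)NC(=O)c1[nH]cnc1-c1nc2ccccc2[nH]1` has not been measured. It differs from compound 2 by tert-butyl in place of 3-cyanophenyl on an amide-type nitrogen. Within the data shown here, the only measured step, a 1.4-fold lower number from compound 1 to compound 2 (0.14 log units; within the scatter), exchanged one cyanophenyl for another and so bears only loosely on replacing the aromatic ring by a small branched chain. Among the measured compounds shown here, no step shows what losing the ring does. The estimate for compound 3 is therefore wide: 40000 nM, between 12000 nM and 130000 nM, a step of a 1.6-fold higher number from compound 2 to compound 3 (0.21 log units; within the scatter) expected to be small and uncertain in direction.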

Compound 3, half-maximal inhibitory concentration: > 40000 nM
Compound 3 ended at the assay's limit; the forecaster's own chance of this, stated with the estimate: 30%; the middle value sits exactly at the limit.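

In this assay compound 3 gives > 40000 nM and this is a limit of the assay, not a number: the limit of > 40000 nM in this assay, at which 1 of the 3 values shown sits.

With tert-butyl on the amide-type nitrogen in place of a cyanophenyl, the steps are an at least 1.6-fold higher number from compound 2 to compound 3 (0.20 log units; that floor lies within the scatter) and an at least 1.1-fold higher number from compound 1 to compound 3 (0.06 log units; that floor lies within the scatter), and each gives only a floor. Among these compounds, this is the first look at this position without an aromatic ring, and the change brings no gain in strength. Any loss may be small or large, as its true size stays hidden behind the limit.

Still open, from the compounds shown here alone, is whether the ring or its nitrile matters more, which a plain phenyl group would help to separate. Also open, going by these compounds, is how this position responds to an amine, a carboxylic acid or a longer carbon chain.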